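The source may report more compounds than this note shows. Statements on the series, on what has been measured and on what is new or still open speak of the compounds shown alone.

Compound 1 `CC1=NN(c2ccccc2)C(=O)C12C=CC(=O)C=C2c1cccc(C)c1` gives 85800 nM in a functional assay on MDA-MB-231 cells (Homo sapiens) for antiproliferative activity, read by CCK-8 assay, with a stated time of 72 h; on this read-out higher numbers stand for weaker inhibition and lower numbers for stronger inhibition. Compound 2 `CC1=NN(c2cccc(Cl)c2)C(=O)C12C=CC(=O)C=C2c1ccc(C)cc1` gives 3820 nM. Compound 3 `CC1=NN(c2ccc(Cl)cc2)C(=O)C12C=CC(=O)C=C2c1cccc(C)c1` gives 26900 nM.

Among these three numbers compound 3 stands second highest: its nearest neighbour is compound 1, whose number is higher, and the furthest is compound 2, whose number is lower. Compound 4 `CC1=NN(c2cccc(Cl)c2)C(=O)C12C=CC(=O)C=C2c1cccc(C)c1` is not yet measured. It differs from compound 3 in that (3-chlorophenyl in place of 4-chlorophenyl on an amide-type nitrogen in a ring); the two compounds contain the same atoms, joined differently.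

Going by the values given here, only one measured step touches the same ring: a 3.2-fold lower number from compound 1 to compound 3 (0.50 log units; beyond the scatter), where the chloro was introduced rather than moved. Among the compounds with values here, no measured pair isolates the shift of the chloro within that ring. Compound 2 carries the same 3-chlorophenyl as compound 4 and gives the lowest number of the three, but it also differs from compound 4 in the methylphenyl group, so its value speaks only loosely for compound 4. On this basis the number for compound 4 is expected to sit between those of compound 3 and compound 2, and the expected step is a 2.7-fold lower number from compound 3 to compound 4 (0.43 log units; beyond the scatter). The estimate for compound 4 is 10000 nM, within a range of 3000 nM to 30000 nM.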

Compound 4, half-maximal inhibitory concentration: 22300 nM
Estimate against measurement, compound 4: 2.2-fold (0.35 log units) below, and the stated range covers the measured number.
By their numbers in this assay, from the lowest: compound 2; then compounds 4 and 3 (each within the scatter of the next); then compound 1.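

In this assay the chloro's place on the phenyl ring on the amide-type nitrogen does not separate the two compounds: the move from 4-chlorophenyl to 3-chlorophenyl gives a 1.2-fold lower number from compound 3 to compound 4 (0.08 log units; within the scatter) and so lies within the usual scatter. Both chloro compounds stand apart from the compound without chloro, with a 3.2-fold lower number from compound 1 to compound 3 (0.50 log units; beyond the scatter) for the 4-chlorophenyl and a 3.8-fold lower number from compound 1 to compound 4 (0.59 log units; beyond the scatter) for the 3-chlorophenyl, so in this small set the presence of the chloro counts for more than its place. With the 3-chlorophenyl held fixed, the place of the methyl on the other phenyl ring does separate the compounds, since 3-methylphenyl in place of 4-methylphenyl on a double-bonded ring carbon gives a 5.8-fold higher number from compound 2 to compound 4 (0.77 log units; beyond the scatter) and lies beyond the scatter.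

Nothing available here gives a reason for either the missing chloro effect of place or the methylphenyl step. As far as these compounds go, it remains open whether the 4-methylphenyl advantage also holds with the 4-chlorophenyl or with the plain phenyl, and whether a methoxy group, an amine or a carboxylic acid in the chloro's place would give numbers like those of the chloro compounds.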